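Removing the Acetyl Group on Two Related Cores

This account rests on a few compounds, and the source may have more. Where it says the series, first, only, none or still open, it means among the compounds named here.

Compound 1 `CC(=O)Nc1ccc2oc(-c3ccc(C(F)(F)F)cc3)cc(=O)c2c1` and compound 2 `Nc1ccc2oc(-c3ccc(C(F)(F)F)cc3)cc(=O)c2c1` share one core and were both tested in an ADME assay on MT4 cells (Homo sapiens) for cytotoxicity, read by MTT assay, with a stated time of 4 days; on this read-out higher numbers stand for lower toxicity in this test and lower numbers for higher toxicity in this test; compound 1 gives 330000 nM and compound 2 gives 273000 nM. The change between them is hydrogen in place of acetyl on a nitrogen on an aromatic ring, and it produced a 1.2-fold lower number from compound 1 to compound 2 (0.08 log units; within the scatter). Compound 3 `COc1c(-c2ccccc2)oc2ccc(NC(C)=O)cc2c1=O` rests on another core; how the two cores differ is not broken down here. In this assay compound 3 gives 200000 nM, a number within the scatter of both compound 1 and compound 2. Compound 4 `COc1c(-c2ccccc2)oc2ccc(N)cc2c1=O` is not yet measured and carries the same change on the core of compound 3: hydrogen in place of acetyl on a nitrogen on an aromatic ring. In this assay compound 4 is expected to give 165000 nM, between 80000 nM and 350000 nM. The expected step is a 1.2-fold lower number from compound 3 to compound 4 (0.08 log units; within the scatter), kept small because the earlier step was a 1.2-fold lower number from compound 1 to compound 2 (0.08 log units; within the scatter).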

Compound 4, half-maximal cytotoxic concentration: 126000 nM
Estimate against measurement, compound 4: 1.3-fold (0.12 log units) above; the measured number falls inside the stated range.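

In this assay the change from acetamido to amino gave a 1.6-fold lower number from compound 3 to compound 4 (0.20 log units; within the scatter), so on this second core the step again stays within the scatter. The change therefore carries from one core to the other with no difference that can be told apart from the scatter: the same change on two cores in this assay, a 1.2-fold lower number (0.08 log units; within the scatter) from compound 1 to compound 2 and a 1.6-fold lower number (0.20 log units; within the scatter) from compound 3 to compound 4, 1.3-fold (0.12 log units) apart, within the scatter of two such steps. This does not show that the change has a real effect on either core, and two pairs cannot show how it would behave on a third core.

The compounds shown leave open how other groups on that nitrogen, such as a methyl group, a longer acyl chain or a sulfonyl group, would read. Also open, on these data alone, is what the methoxy and trifluoromethyl groups contribute on their own.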